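Shortening the amine chain on a chlorinated biaryl

A few compounds are considered here, and "the series" means these few. Any claim that something is new, unique, unknown or untested is made for them only; others in the source may bear on it.

Compound 1 `CCNCc1ccc(Cl)c(-c2ccccc2OC)c1` gives a largest response of 71% in a functional assay on HEK293 cells for agonist activity at 5-hydroxytryptamine receptor 7 (Homo sapiens), read by cAMP accumulation, with a stated time of 30 min; on this read-out higher numbers stand for larger maximal responses and lower numbers for smaller maximal responses. Compound 2 `CCCCNCc1ccc(Cl)c(-c2ccccc2OC)c1` is a butyl analogue of the ethyl compound 1. In this assay, within the data shown here, compound 2 is reported as "not active" (no number reported), so no number places compound 2 on the same scale; the two values show only that the butyl compound gave no measurable response where the ethyl one gave a sizable response. Compound 3 `CNCc1ccc(Cl)c(-c2ccccc2OC)c1` has not yet been measured. The change from compound 2 to compound 3 is hydrogen in place of propyl on a saturated chain carbon bound to an amine nitrogen. Among the measured compounds shown here, no step between measured compounds is available, so the expectation in this assay rests on compound 1 and its value of 71%: with butylamino cut back to methylamino, a large move upward from the inactive compound 2 is expected rather than none. Compound 3 is expected to give a largest response of 75% in this assay, estimated to lie between 45% and 100%.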

Compound 3, largest response reached (Emax), in percent of the reference or control that the assay uses: 72%
Estimate against measurement, compound 3: 3 percentage points above; low and high end bracket the measured number.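

Hydrogen in place of methyl on a saturated chain carbon bound to an amine nitrogen gives a number 1 percentage points higher from compound 1 to compound 3 (within the scatter) in this assay, so the methylamino and ethylamino compounds stand level on this read-out and the sizable response is not tied to the ethyl chain alone. Compound 2 is reported only as not active, so its steps to the other two compounds cannot be read as numbers, yet among these three compounds the butyl chain alone goes with no measurable response. No measurement shown here offers an explanation for this pattern.

As far as these compounds go, what remains open is where along the chain the response disappears, as a propyl chain on the amine lies outside these compounds. Also open, from the compounds shown here alone, is how a primary amine or a branched isopropyl group at this place would behave.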